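The compounds below may be only part of what the source reports. "The series", "measured", "known", "first", "only" and "open" are said of these compounds alone.

In a functional assay on A549 cells (Homo sapiens) for cytotoxicity, read by sulforhodamine B assay, with a stated time of 72 h (a lower number here means a stronger inhibitor, a higher number a weaker inhibitor), compound 1 `CCCC(=O)Nc1ccn([C@@H]2CO[C@H](CO)O2)c(=O)n1` gives 6600 nM, and compound 2 `CCCCCCCCC(=O)Nc1ccn([C@@H]2CO[C@H](CO)O2)c(=O)n1`, with a longer chain on the shared core, gives 46 nM, the lower of the two numbers. Compound 3 `CCCCCCCCCCCCCCCCCCCC(=O)Nc1ccn([C@@H]2CO[C@H](CO)O2)c(=O)n1` has not yet been measured. It lengthens that chain again: undecyl in place of hydrogen on a saturated chain carbon, eight bonds along the chain from a carbonyl carbon. Among the compounds with values here, only one measured step bears on this change, the earlier chain extension, which gave a 140-fold lower number from compound 1 to compound 2 (2.16 log units; beyond the scatter), a large step beyond the scatter. A single step cannot show how far such a trend continues, and the new extension is longer than the measured one. No further large gain is therefore assumed, and the expected outcome is no change beyond the scatter, with a wide margin in both directions. The estimated step is a 1.1-fold higher number from compound 2 to compound 3 (0.04 log units; within the scatter). For compound 3 the expected value is 50 nM, within an estimated range of 8 nM to 400 nM.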

Compound 3, half-maximal inhibitory concentration: 30 nM
Compound 3: the middle estimate sits 1.7-fold (0.22 log units) above what was measured; the range from low to high includes it.
By their numbers in this assay, from the lowest: compounds 3 and 2 (each within the scatter of the next); then compound 1.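

At this position, the chain length that matters in this assay is not simply "the longer the better". The first extension gave a 140-fold lower number from compound 1 to compound 2 (2.16 log units; beyond the scatter), but adding a much larger undecyl group at the same place gave a 1.5-fold lower number from compound 2 to compound 3 (0.19 log units; within the scatter), so compound 2 and compound 3 cannot be told apart in this assay. The large gain therefore does not carry on in proportion to the added carbon, and a very long saturated chain is tolerated here without a clear loss. No available evidence explains why the second extension differs from the first.

The compounds shown leave open how the numbers behave for chains of intermediate length between those of compound 2 and compound 3. They also leave open what an amine or a carboxylic acid at the far end of the chain would do.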